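The source may report more compounds than this note shows. Statements on the series, on what has been measured and on what is new or still open speak of the compounds shown alone.

Series notes. In a functional assay on U-373MG ATCC cells (Homo sapiens) for inhibition, read by MTT assay, with a stated time of 72 h (a higher number here means a weaker inhibitor, a lower number a stronger inhibitor), compound 1 (`COc1ccccc1NC(=S)NC1CC(C)(C)Oc2ccc(Br)cc21`) gives 22000 nM and compound 2 (`CC1(C)CC(NC(=S)Nc2ccc(C#N)cc2)c2cc(Br)ccc2O1`) gives 22000 nM, so compound 2 stands level with compound 1. The next structure is compound 3 (`CC1(C)CC(NC(=S)Nc2ccccc2Cl)c2cc(Br)ccc2O1`), which differs from compound 2 as follows: 2-chlorophenyl in place of 4-cyanophenyl on an amide-type nitrogen. The group changes on an amide-type nitrogen, with the thiocarbonyl carbon as that nitrogen's other neighbour. For the measured compounds named here, only one measured step bears on this change, since it swaps groups at the same place: no change at the digits printed from compound 1 to compound 2 (within the scatter). That step replaced 2-methoxyphenyl with 4-cyanophenyl and left the value in this assay unmoved, but a single step is thin evidence. No step beyond the scatter is therefore expected here, and the expected result is a 1.1-fold lower number from compound 2 to compound 3 (0.04 log units; within the scatter). The estimated value for compound 3 is 20000 nM, with an expected range of 10000 nM to 40000 nM.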

Compound 3, half-maximal inhibitory concentration: 34000 nM
Estimate against measurement, compound 3: 1.7-fold (0.23 log units) below; the range from low to high includes it.
By their numbers in this assay, from the lowest: compounds 1, 2 and 3 (each within the scatter of the next).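

In this assay, the 2-chlorophenyl group of compound 3 gives a third aryl group on the amide-type nitrogen, and the reading stays inside the scatter (a 1.5-fold higher number from compound 2 to compound 3 (0.19 log units; within the scatter)). The comparison with the 2-methoxyphenyl group, chloro in place of methoxy on an aromatic carbon, also stays inside it (a 1.5-fold higher number from compound 1 to compound 3 (0.19 log units; within the scatter)), so the three aryl groups cannot be told apart at this place, and a second step now agrees with the first. No measurement shown offers any explanation for this reading.

Still open, from the compounds shown here alone, is whether any group on this nitrogen moves the number beyond the scatter: an amine or a carboxylic acid on the phenyl group, or a longer chain in place of it, would test that. Going by these compounds, all three compounds keep the shared core, so the contribution of its bromo group also remains unknown.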